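A few compounds are considered here, and "the series" means these few. Any claim that something is new, unique, unknown or untested is made for them only; others in the source may bear on it.

Compound 1 `Clc1cc2nc(-c3cc4ccccc4n3Cc3ccccc3)[nH]c2cc1Cl`: 22500 nM
Compound 2 `Cc1cc(C)c2nc(-c3cc4ccccc4[nH]3)[nH]c2c1`: 24800 nM

In a functional assay on T47D cells (Homo sapiens) for antiproliferative activity, read by MTT assay, with a stated time of 48 h (a higher number here means a weaker inhibitor, a lower number a stronger inhibitor), compound 1 and compound 2 lie within the scatter of each other, so neither ranks ahead on these numbers. Compound 3 `Clc1cc2nc(-c3cc4ccccc4[nH]3)[nH]c2cc1Cl` has hydrogen in place of benzyl on an aromatic nitrogen relative to compound 1 (hydrogen in place of benzyl on an aromatic nitrogen). Among the measured compounds shown here, no measured step covers this change, so the expectation is weakly grounded. No shift beyond the scatter is expected in this assay, and no direction is favoured. The estimated step of a 1.1-fold higher number from compound 1 to compound 3 (0.05 log units; within the scatter) is correspondingly small. Compound 3 is estimated at 25000 nM, with an expected range of 10000 nM to 60000 nM.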

Compound 3, half-maximal inhibitory concentration: 21200 nM
The estimate for compound 3 lay 1.2-fold (0.07 log units) above the measured number; low and high end bracket the measured number.
By their numbers in this assay, from the lowest: compounds 3, 1 and 2 (each within the scatter of the next).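

Among the compounds shown here, replacing benzyl with hydrogen on the aromatic nitrogen gives the first measured step at this position in this assay (a 1.1-fold lower number from compound 1 to compound 3 (0.03 log units; within the scatter)). On the core of compound 1, this position therefore carries either benzyl or hydrogen without a shift beyond the scatter, although a six-membered aromatic ring leaves with the benzyl. No supporting data bear on this result.

As far as these compounds go, whether a methyl, an acetyl or a longer chain ending in an amine on this nitrogen would read the same remains open. So does whether the same step would hold on another core.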